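From Thiophen-2-yl to Furan-2-yl on a Shared Core

The compounds below may be only part of what the source reports. "The series", "measured", "known", "first", "only" and "open" are said of these compounds alone.

Compound 3 `c1ccc(-c2cc(-c3cccs3)cc(-c3ccccn3)n2)nc1` gives 0.44 ug/mL in a functional assay on A549 cells (Homo sapiens) for antiproliferative activity (a higher number here means a weaker inhibitor of growth, a lower number a stronger inhibitor of growth), the lowest of the three numbers at hand. Compound 1 `c1ccc(-c2cc(-c3ccsc3)cc(-c3ccccn3)n2)nc1` gives 0.62 ug/mL in this assay, a number within the scatter of compound 3, while compound 2 `c1ccc(-c2cc(-c3cccs3)cc(-c3ccncc3)n2)nc1` gives 36.2 ug/mL, far above it. Two steps lead to compound 3. The step of a 1.4-fold lower number from compound 1 to compound 3 (0.15 log units; within the scatter) changed the same five-membered ring that is changed here and stayed within the scatter. The step of an 82-fold lower number from compound 2 to compound 3 (1.92 log units; beyond the scatter) concerned a different group on the shared core and was large.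

Compound 4 `c1ccc(-c2cc(-c3ccco3)cc(-c3ccccn3)n2)nc1` differs from compound 3 in one place: furan-2-yl in place of thiophen-2-yl on an aromatic carbon. Among the compounds with values here, the only measured step that bears on this position is the small one, so no large movement is expected. The step is estimated as a 1.6-fold higher number from compound 3 to compound 4 (0.20 log units; within the scatter), with no direction that would clearly exceed the scatter. Compound 4 is therefore expected to give about 0.7 ug/mL in this assay, within a range from 0.25 ug/mL to 2.5 ug/mL.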

Compound 4, concentration for 50% growth inhibition: 0.22 ug/mL
Compound 4: middle estimate off by 3.2-fold (0.50 log units), on the high side, and the stated range ends above it.
By their numbers in this assay, from the lowest: compounds 4, 3 and 1 (each within the scatter of the next, the first and the last beyond it); then compound 2.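

In this assay the exchange of sulfur for oxygen in the five-membered ring gave a 2.0-fold lower number from compound 3 to compound 4 (0.30 log units; within the scatter) and so does not separate furan-2-yl from thiophen-2-yl on this carbon. Furan-2-yl does separate from thiophen-3-yl, with a 2.8-fold lower number from compound 1 to compound 4 (0.45 log units; beyond the scatter) as the only step at this position that lies beyond the scatter, so the choice of five-membered ring can shift the number here, though only modestly. Nothing in the data at hand explains this difference.

Every group shown on this carbon is a five-membered aromatic ring with one hetero atom, so the effect of a phenyl ring, an amine or a longer chain here remains open. Also open, from the compounds shown here alone, is how furan-2-yl would fare alongside the pyridin-4-yl group of compound 2.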